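The source may report more compounds than this note shows. Statements on the series, on what has been measured and on what is new or still open speak of the compounds shown alone.

Measured in a functional assay on HeLa cells (Homo sapiens) for cytotoxicity, read by sulforhodamine B assay; on this read-out lower numbers stand for stronger inhibition and higher numbers for weaker inhibition:

Compound 1 `Cn1c2c(c3ccccc3c1=O)CCOc1ccccc1-2`: compound 1 gives 19700 nM
Compound 2 `Cc1ccc2c(=O)n(C)c3c(c2c1)CCOc1ccccc1-3`: compound 2 gives 41600 nM
Compound 3 `COc1ccc(Cn2c(-c3ccccc3O)c(Br)c3ccccc3c2=O)cc1`: compound 3 gives 36800 nM

Compound 1 and compound 2 share a core and differ by one change, (methyl in place of hydrogen on an aromatic carbon). In this assay that change gave a 2.1-fold higher number from compound 1 to compound 2 (0.32 log units; beyond the scatter), a modest step beyond the scatter toward weaker inhibition.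

Compound 3 carries a different core; how the two cores differ is not broken down here. Its value and that of compound 2 sit within the scatter of each other, as do its value and that of compound 1, so no order is read among them.

Compound 4 `COc1ccc(Cn2c(-c3ccccc3O)c(Br)c3cc(C)ccc3c2=O)cc1` is not yet measured. It differs from compound 3 by methyl in place of hydrogen on an aromatic carbon. This is the same kind of change as that from compound 1 to compound 2, though the ring bearing the methyl belongs to a fused or bridged system of two rings rather than four.

Going by the values given here, the expectation for compound 4 rests on the one precedent, a 2.1-fold higher number from compound 1 to compound 2 (0.32 log units; beyond the scatter), applied to compound 3. A step of about a 1.8-fold higher number from compound 3 to compound 4 (0.25 log units; within the scatter) is expected, giving an estimate for compound 4 of 65000 nM, with a likely range from 30000 nM to 140000 nM.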

Compound 4, half-maximal inhibitory concentration: 20400 nM
Compound 4: the middle estimate sits 3.2-fold (0.50 log units) above what was measured; the measured number lies below the stated range.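

In this assay, methyl in place of hydrogen on an aromatic carbon gives a 1.8-fold lower number from compound 3 to compound 4 (0.26 log units; within the scatter) on the core of compound 3, so no effect of the methyl can be read on that core. The change therefore does not carry over at a constant size from the core of compound 1 to the core of compound 3: the same change on two cores in this assay, a 2.1-fold higher number (0.32 log units; beyond the scatter) from compound 1 to compound 2 and a 1.8-fold lower number (0.26 log units; within the scatter) from compound 3 to compound 4, 3.8-fold (0.58 log units) apart, beyond the scatter of two such steps This shows that the step on one core is a poor guide to the step on the other, but it does not show a true reversal of direction, since the second step stays within the scatter, and with a single pair per core it gives no reason for the gap.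

The compounds shown leave open how an amine, a carboxylic acid or a longer chain in place of the methyl would read in this assay. Also open, from the compounds shown here alone, is whether further pairs on each core would confirm the gap between the two steps.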